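A few compounds are considered here, and "the series" means these few. Any claim that something is new, unique, unknown or untested is made for them only; others in the source may bear on it.

Measured so far:
compound 1, `O=C1c2c[n+]([O-])c3ccccc3c2C(=O)c2c1c1ccccc1n2Cc1cn([C@H]2C[C@H](O)[C@@H](CO)O2)nn1`: 620 nM
compound 2, `O=C1c2c[n+]([O-])c3ccccc3c2C(=O)c2c1c1ccccc1n2Cc1cn(C[C@@H](O)CO)nn1`: > 500 nM
compound 3, `O=C1c2c[n+]([O-])c3ccccc3c2C(=O)c2c1c1ccccc1n2Cc1cn([C@H]2O[C@H](CO)[C@@H](O)[C@H]2O)nn1`: 1340 nM

All three were read in a functional assay on SH-SY5Y cells (Homo sapiens) for cytotoxicity, read by MTT assay, with a stated time of 72 h; on this read-out higher numbers stand for weaker inhibition and lower numbers for stronger inhibition. For compound 2 the value > 500 nM is a limit of the assay, not a number. Owing to the limit of > 500 nM in this assay, at which 1 of the 3 values shown sits, the steps a step that the limit leaves unreadable from compound 1 to compound 2 and a step that the limit leaves unreadable from compound 2 to compound 3 cannot be sized. Within the data shown here, the only readable step is a 2.2-fold higher number from compound 1 to compound 3 (0.33 log units; beyond the scatter), a modest shift between two sugar-type groups on the aromatic nitrogen.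

Compound 4, `CN(C)CCCCn1c2c(c3ccccc31)C(=O)c1c[n+]([O-])c3ccccc3c1C2=O`, differs from compound 2 by 3-(dimethylamino)propyl in place of 1-(2,3-dihydroxypropyl)-1H-1,2,3-triazol-4-yl on a saturated chain carbon bound to an aromatic nitrogen. Among the measured compounds shown here, no measured step involves this chain, so nothing here sizes its effect. Compound 4 is therefore expected near 900 nM, within 200 nM to 4000 nM. The step that the limit leaves unreadable from compound 2 to compound 4 is the estimate this implies.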

Compound 4, half-maximal inhibitory concentration: 250 nM
For compound 4 the middle estimate is 3.6-fold (0.56 log units) above the measured one, and the stated range covers the measured number.
By their numbers in this assay, from the lowest: compound 4; then compound 1; then compound 3.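

At this saturated chain carbon bound to an aromatic nitrogen, replacing 1-(2,3-dihydroxypropyl)-1H-1,2,3-triazol-4-yl with 3-(dimethylamino)propyl gives an at least 2.0-fold lower number from compound 2 to compound 4 (0.30 log units; that floor lies within the scatter). This is the first change shown that removes the whole 1-(2,3-dihydroxypropyl)-1H-1,2,3-triazol-4-yl group, not just the group on its aromatic nitrogen. The value of compound 2 is a limit, so the true size of this step, like that of the other steps involving compound 2, cannot be read: the limit of > 500 nM in this assay, at which 1 of the 4 values shown sits.

Still open, as far as these compounds go, is whether the amine matters, or only the loss of the 1-(2,3-dihydroxypropyl)-1H-1,2,3-triazol-4-yl group. A plain butyl chain without an amine, or a pyrrolidine in place of the dimethylamino group, would help separate the two.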